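A Hydroxyethyl Amide in a Rat Paw Edema Series

The compounds below may be only part of what the source reports. "The series", "measured", "known", "first", "only" and "open" are said of these compounds alone.

Compound 1 `CCCCCNC(=O)CC1CCc2cc(OC)c(OC)cc21` was tested in a functional assay on the whole organism (strain Wistar) for inhibition, with Rattus norvegicus as the target, read by paw edema, with stated times of 60 min and 2 h, at a dose of 100 mg/kg by the oral route (a lower number here means less inhibition, a higher number more inhibition at the dose given (going by the name of the read-out)), where compound 1 gives 34%. Compound 2 `COc1cc2c(cc1OC)C(CC(=O)N1CCCC1)CC2` gives 20% in the same assay. Among the measured compounds shown here, the only step so far is a number 14 percentage points lower from compound 1 to compound 2 (beyond the scatter), so compound 1 stands highest of the two numbers. Compound 3 `COc1cc2c(cc1OC)C(CC(=O)NCCO)CC2` differs from compound 1 by hydroxy in place of propyl on a saturated chain carbon, two bonds along the chain from an amide-type nitrogen, turning pentylamino into (2-hydroxyethyl)amino. The measured step alters the same amide-type nitrogen, though differently, and it lowered inhibition modestly, so for compound 3 a small downward change is expected, a number 9 percentage points lower from compound 1 to compound 3 (within the scatter), giving an estimated 25% in this assay, within the range 5% to 45%.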

Compound 3, a percentage reported as inhibition, in the whole organism at one dose (the size of the read-out at that dose, not a potency): 0%
Estimate against measurement, compound 3: 25 percentage points above, and the stated range ends above it.
By their numbers in this assay, from the lowest: compound 3; then compound 2; then compound 1.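

Among the compounds shown here, the pentylamino side chain matters more than the one earlier step suggested: replacing its propyl part with hydroxy gives a number 34 percentage points lower from compound 1 to compound 3 (beyond the scatter) in this assay. The pyrrolidin-1-yl amide also keeps more inhibition than the (2-hydroxyethyl)amino amide, with a number 20 percentage points lower from compound 2 to compound 3 (beyond the scatter), so at this dose the (2-hydroxyethyl)amino group gives the lowest number of the three. No measurement here gives a reason for this drop. Still open, from the compounds shown here alone, is whether 2-methoxyethyl or 2-aminoethyl on the amide-type nitrogen would restore inhibition, and whether a longer chain ending in hydroxy would do so.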